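The source may report more compounds than this note shows. Statements on the series, on what has been measured and on what is new or still open speak of the compounds shown alone.

Among the compounds with values here, compound 2 `CCCS(=O)(=O)c1cccc(C#Cc2cc(C#N)ccc2OCC(=O)O)c1` stands at the lower of the two numbers measured so far: in an assay on CHO cells for displacement of a labelled ligand from prostaglandin D2 receptor 2 (Homo sapiens), read by scintillation counting (on this read-out higher numbers stand for weaker inhibition and lower numbers for stronger inhibition), compound 2 gives 21 nM, while compound 1 `CCCS(=O)(=O)c1cccc(C#Cc2cc(F)ccc2OCC(=O)O)c1` gives 65 nM. Within the data shown here, the one step measured, a 3.1-fold lower number from compound 1 to compound 2 (0.49 log units; beyond the scatter), concerns a change on the ring that carries the acetic acid chain.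

Compound 3 `CCCS(=O)(=O)c1ccc(C)c(C#Cc2cc(C#N)ccc2OCC(=O)O)c1` differs from compound 2 by methyl in place of hydrogen on an aromatic carbon, on an aromatic carbon of a six-membered aromatic ring of carbon only, para to a propylsulfonyl group. Among the measured compounds shown here, no measured step touches this ring, so the single step from compound 1 to compound 2 gives no direct guidance, and the change is small. The number for compound 3 is therefore expected to stay within the scatter of compound 2, a step of a 1.0-fold higher number from compound 2 to compound 3 (0.02 log units; within the scatter). In this assay compound 3 is estimated at 22 nM, in a range from 8 nM to 60 nM.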

Compound 3, inhibition constant: 7 nM
Beside the measured number, compound 3's estimate is 3.1-fold (0.50 log units) above it, outside the stated range (below it).
By their numbers in this assay, from the lowest: compound 3; then compound 2; then compound 1.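

In this assay, methyl in place of hydrogen, para to a propylsulfonyl group and ortho to a large group, gives a 3.0-fold lower number from compound 2 to compound 3 (0.48 log units; beyond the scatter), so even one added carbon on this ring can move the number beyond the scatter. The ring carrying the propylsulfonyl group is therefore a second place where a small change counts, alongside a 3.1-fold lower number from compound 1 to compound 2 (0.49 log units; beyond the scatter) on the ring with the acetic acid chain. No measurement shown here accounts for the gain from this methyl.

On these data alone, only hydrogen and methyl appear at this position, so it remains open whether an ethyl, a methoxy group or an amine there would lower the number further or raise it. As far as these compounds go, it is also open whether the methyl would give a similar step in a compound carrying fluoro instead of cyano, as compound 1 does.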